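The compounds below may be only part of what the source reports. "The series", "measured", "known", "first", "only" and "open" are said of these compounds alone.

Measured in a functional assay on the whole organism with Rattus norvegicus as the target; a lower number here means that less compound is needed, a higher number that more compound is needed for the effect:
compound 1 `CCOCCOC(=O)C(=O)Nc1nc(-c2cc(Cl)no2)cs1`: > 30 mg/kg
compound 2 `CCOCCOC(=O)C(=O)Nc1nc(-c2cc(Br)no2)cs1`: > 30 mg/kg
compound 3 `CCOCCOC(=O)C(=O)Nc1nc(-c2conc2C)cs1`: > 100 mg/kg

All three entries are limits, not numbers. Compound 1 therefore stands only at the limit of > 30 mg/kg.

Compound 4 `O=C(O)C(=O)Nc1nc(-c2cc(Cl)no2)cs1` has hydrogen in place of 2-ethoxyethyl on an oxygen next to a carbonyl group. The measured steps, a step that the two limits leave unreadable from compound 1 to compound 2, a step that the two limits leave unreadable from compound 1 to compound 3 and a step that the two limits leave unreadable from compound 2 to compound 3, all keep the 2-ethoxyethyl group and give no readable size, so they offer no guide to this change. The expected a number no higher from compound 1 to compound 4 (the limit leaves the size open) therefore carries no firm direction, and another limit is a likely outcome. For compound 4 the estimate is 30 mg/kg, with an expected range of 6 mg/kg to 150 mg/kg.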

Compound 4, dose for half-maximal effect: > 30 mg/kg
Compound 4 was reported as a limit; the forecaster's own chance of this, stated with the estimate: 50%; the middle value lies on the limit itself.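

In this assay compound 4 gives > 30 mg/kg, a limit and not a number. Compound 1 also stands at a limit, and the step between compound 1 and compound 4 cannot be read. The compounds shown leave open what hydroxy in place of 2-ethoxyethoxy does to the dose needed.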